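Two Stereocentres Inverted: What to Expect for Compound 4

The source may hold more compounds than are shown below. What is called first, only, known or untested is meant among the compounds shown, and "the series" means these compounds.

Three glycosylated compounds have been tested in a functional assay on SK-MEL-2 cells (Homo sapiens) for cytotoxicity, read by sulforhodamine B assay; on this read-out higher numbers stand for weaker inhibition and lower numbers for stronger inhibition. Compound 1 `COc1cc([C@H]2Oc3c(OC)cc(CCCO)cc3[C@@H]2CO[C@@H]2O[C@@H](C)[C@H](O)[C@@H](O)[C@H]2O)cc(OC)c1O` gives > 10000 nM in this assay, which is a limit rather than a number. Compound 2 `COc1cc(C[C@@H]2CO[C@@H](c3cc(OC)c(O)c(OC)c3)[C@@H]2CO[C@@H]2O[C@@H](C)[C@H](O)[C@@H](O)[C@H]2O)cc(OC)c1O` likewise gives > 10000 nM, again a limit. Compound 3 `COc1cc(C[C@@H]2CO[C@@H](c3ccc(O)c(OC)c3)[C@@H]2CO[C@@H]2O[C@@H](C)[C@H](O)[C@@H](O)[C@H]2O)ccc1O` also gives > 10000 nM, a limit as well. Compound 2 therefore stands exactly where the other measured compounds stand: at the limit, with no number to rank it against the others. the limit of > 10000 nM in this assay, at which 3 of the 3 values shown sit, sums up the whole picture.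

Compound 4 `COc1cc(C[C@H]2CO[C@@H](c3cc(OC)c(O)c(OC)c3)[C@H]2CO[C@@H]2O[C@@H](C)[C@H](O)[C@@H](O)[C@H]2O)cc(OC)c1O` is the open question. Compared with compound 2, (the two compounds have the same atoms and bonds and differ only in configuration as drawn: 2 of 8 stereo elements differ; a stereocentre at a saturated ring carbon is drawn S in compound 2 and R in compound 4; a stereocentre at a saturated ring carbon is drawn S in compound 2 and R in compound 4). For the measured compounds named here, no measured pair differs in only one place, so there is no measured step to lean on. Because of the limit of > 10000 nM in this assay, at which 3 of the 3 values shown sit, the expected step from compound 2 to compound 4 is a step that the limit leaves unreadable from compound 2 to compound 4, that is, none beyond the scatter. Compound 4 is estimated to come out at 20000 nM, within a range of 8000 nM to 60000 nM, and most likely to be reported as a limit once more.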

Compound 4, half-maximal inhibitory concentration: > 10000 nM
Compound 4 gave a limit, no number (the forecaster's own chance of this, stated with the estimate: 85%); the middle value is on the limit's open side.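

Compound 2 and compound 4 both gave only a limit in this assay, so no step can be read between them. The compounds shown leave open whether inverting the two stereocentres changes activity at all, and how any of these compounds ranks against the others.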